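The source may hold more compounds than are shown below. What is called first, only, known or untested is meant among the compounds shown, and "the series" means these compounds.

Measured in a functional assay on A549 cells (Homo sapiens) for cytotoxicity, read by MTT assay, with a stated time of 72 h; a higher number here means a weaker inhibitor, a lower number a stronger inhibitor:

Compound 1, `CC1CCN(Cc2ccc3nc(NC(=O)N/N=C/c4cn(Cc5ccc(Cl)cc5Cl)c5ccccc45)sc3c2)CC1`, gives 3640 nM.
Compound 2, `CCN(CC)Cc1ccc2nc(NC(=O)N/N=C/c3cn(Cc4ccc(Cl)cc4Cl)c4ccccc34)sc2c1`, gives 1900 nM.
Compound 3, `CCN(CC)Cc1ccc2nc(NC(=O)N/N=C/c3cn(Cc4ccc(C)cc4)c4ccccc34)sc2c1`, gives 1510 nM.

Compound 2 and compound 1 differ in one place: 4-methylpiperidin-1-yl in place of diethylamino on a saturated chain carbon bound to an aromatic carbon. The measured step is a 1.9-fold higher number from compound 2 to compound 1 (0.28 log units; within the scatter). Compound 2 and compound 3 differ in their cores: 4-methylphenyl in place of 2,4-dichlorophenyl on a saturated chain carbon bound to an aromatic nitrogen, with step a 1.3-fold lower number from compound 2 to compound 3 (0.10 log units; within the scatter). Compound 3 and compound 1 differ in both places; their values stand beyond the scatter of each other.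

Compound 4, `Cc1ccc(Cn2cc(/C=N/NC(=O)Nc3nc4ccc(CN5CCC(C)CC5)cc4s3)c3ccccc32)cc1`, is not yet measured. It differs from compound 3 as 4-methylpiperidin-1-yl in place of diethylamino on a saturated chain carbon bound to an aromatic carbon; the place line is word for word that of the change from compound 2 to compound 1, so this is the same change made on the core of compound 3. The expected step is a 1.9-fold higher number from compound 3 to compound 4 (0.28 log units; within the scatter), resting on a 1.9-fold higher number from compound 2 to compound 1 (0.28 log units; within the scatter). For compound 4 the estimate is 2900 nM, with a range from 1500 nM to 5600 nM.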

Compound 4, half-maximal inhibitory concentration: 2180 nM
Compound 4: middle estimate off by 1.3-fold (0.12 log units), on the high side; measured number inside the range.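

In this assay, 4-methylpiperidin-1-yl in place of diethylamino gives a 1.4-fold higher number from compound 3 to compound 4 (0.16 log units; within the scatter), and this agrees with the same change on the other core: the same change on two cores in this assay, a 1.9-fold higher number (0.28 log units; within the scatter) from compound 2 to compound 1 and a 1.4-fold higher number (0.16 log units; within the scatter) from compound 3 to compound 4, 1.3-fold (0.12 log units) apart, within the scatter of two such steps. On the pair carrying 4-methylpiperidin-1-yl, 4-methylphenyl in place of 2,4-dichlorophenyl gives a 1.7-fold lower number from compound 1 to compound 4 (0.22 log units; within the scatter), which also agrees with the same change on the other core: the same change on two cores in this assay, a 1.3-fold lower number (0.10 log units; within the scatter) from compound 2 to compound 3 and a 1.7-fold lower number (0.22 log units; within the scatter) from compound 1 to compound 4, 1.3-fold (0.12 log units) apart, within the scatter of two such steps. Both changes therefore carry across these two cores without a resolved difference, but each step lies within the scatter, so this does not show that either change has a real effect, nor that a larger step would carry over.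

Still open, going by these compounds, is whether another group on a saturated chain carbon bound to an aromatic carbon, such as morpholin-4-yl or a primary amine, would give a step beyond the scatter. The same question stands for 4-methoxyphenyl or a pyridine ring on a saturated chain carbon bound to an aromatic nitrogen.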